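Notes on the shared core: compound 3 to compound 4

A few compounds are considered here, and "the series" means these few. Any claim that something is new, unique, unknown or untested is made for them only; others in the source may bear on it.

Compound 1 `CCOC(=O)C1=Cc2ccccc2OC1(OCc1cn(CC(=O)Nc2cccc(F)c2)nn1)C(F)(F)F` in a functional assay on DU-145 cells (Homo sapiens) for inhibition, read by MTT assay, with a stated time of 24 h (a higher number here means a weaker inhibitor, a lower number a stronger inhibitor), is reported only as a limit, > 150000 nM.
Compound 2 `CCOC(=O)C1=Cc2ccccc2OC1(OCc1cn(CC(=O)Nc2ccc(C)cc2)nn1)C(F)(F)F` in this assay likewise sits at a limit, > 150000 nM.
Compound 3 `CCOC(=O)C1=Cc2ccccc2OC1(OCc1cn(-c2ccc(F)c(Cl)c2)nn1)C(F)(F)F` in this assay gives 21500 nM.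

Compound 3 holds the only number shown; the other two values are limits, so the step that the two limits leave unreadable from compound 1 to compound 2 cannot be read. Against those limits stand an at least 6.9-fold lower number from compound 1 to compound 3 (0.84 log units; beyond the scatter) and an at least 6.9-fold lower number from compound 2 to compound 3 (0.84 log units; beyond the scatter), both of which exchange a carbamoylmethyl group for a ring set directly on the aromatic nitrogen. Compound 4 `CCOC(=O)C1=Cc2ccccc2OC1(OCc1cn(-c2cccc(C(F)(F)F)c2)nn1)C(F)(F)F` keeps that direct ring attachment: 3-(trifluoromethyl)phenyl in place of 3-chloro-4-fluorophenyl on an aromatic nitrogen. Among the measured compounds shown here, no measured step exchanges one such directly attached ring for another, so the steps to hand bear on it only indirectly: they show that with a directly attached ring compound 3 stands clear of the limit (the limit of > 150000 nM in this assay, at which 2 of the 3 values shown sit), and they give no reading of how far a change within that ring moves the number. The expectation is therefore a step in this assay of no certain direction, a 1.0-fold higher number from compound 3 to compound 4 (0.01 log units; within the scatter), within the usual scatter. Compound 4 is estimated at 22000 nM, with a range from 7000 nM to 70000 nM.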

Compound 4, half-maximal inhibitory concentration: > 150000 nM
Compound 4: a limit, no number; the forecaster's own chance of this, stated with the estimate: 15%; middle value at least 6.8-fold (0.83 log units) away from the limit.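

In this assay, among the compounds shown here, setting 3-(trifluoromethyl)phenyl in place of 3-chloro-4-fluorophenyl on the aromatic nitrogen gives an at least 6.9-fold higher number from compound 3 to compound 4 (0.84 log units; beyond the scatter), the first reading of a change within a directly attached ring. A directly attached ring therefore does not by itself bring a compound clear of the limit; among the two such rings shown, only the 3-chloro-4-fluorophenyl of compound 3 does so, and what the ring carries matters at this position. Compound 4 is reported only as a limit, > 150000 nM, so its steps to compound 1 and compound 2 join two limits and cannot be read.

For the compounds shown here, with compound 3 the only one carrying a number, the size of the change at this position has a lower bound but no measured value, and no trend among ring substituents can be drawn: the limit of > 150000 nM in this assay, at which 3 of the 4 values shown sit. Still open, from the compounds shown here alone, is whether the chlorine or the fluorine of compound 3 alone would hold the reading, and whether a directly attached phenyl ring bearing an amine, a methoxy group or a carboxylic acid would give a number in this assay.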